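The compounds below may be only part of what the source reports. "The series", "measured", "known", "first", "only" and "open" are said of these compounds alone.

Compound 2 `CN(C)c1ccc(Nc2nccc(-c3ccsc3)n2)cc1` gives 2100 nM in a functional assay for inhibition, with Homo sapiens as the target (on this read-out higher numbers stand for weaker inhibition and lower numbers for stronger inhibition), and compound 1 `COc1ccc(Nc2nccc(-c3ccsc3)n2)cc1` gives 15600 nM in this assay. Among the measured compounds shown here, the one change between them, (methoxy in place of dimethylamino on an aromatic carbon), made a 7.4-fold higher number from compound 2 to compound 1 (0.87 log units; beyond the scatter). Compound 3 `CN(C)c1cccc(Nc2nccc(-c3cccs3)n2)c1` gives 2400 nM in this assay; the difference between its core and the core of compound 2 is not broken down here. Compound 4 `COc1cccc(Nc2nccc(-c3cccs3)n2)c1` has not yet been measured. It differs from compound 3 by methoxy in place of dimethylamino on an aromatic carbon, the same kind of change as before, except that here the place is meta to a large group where before it was para to a large group. Because of a 7.4-fold higher number from compound 2 to compound 1 (0.87 log units; beyond the scatter) a weakening of similar size is expected, so compound 4 is estimated to show a 5.8-fold higher number from compound 3 to compound 4 (0.77 log units; beyond the scatter). Compound 4 is expected to come out near 14000 nM, between 5000 nM and 40000 nM.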

Compound 4, half-maximal inhibitory concentration: 900 nM
Beside the measured number, compound 4's estimate is 16-fold (1.19 log units) above it; measured number below the stated range.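

Putting methoxy in place of dimethylamino gave a 2.7-fold lower number from compound 3 to compound 4 (0.43 log units; beyond the scatter), so the number fell on this core, whereas the same change raised it on the earlier one. In this assay, the effect of this change therefore did not carry over from one core to the other, in either direction or size: the same change on two cores in this assay, a 7.4-fold higher number (0.87 log units; beyond the scatter) from compound 2 to compound 1 and a 2.7-fold lower number (0.43 log units; beyond the scatter) from compound 3 to compound 4, 20-fold (1.30 log units) apart, beyond the scatter of two such steps

This does not show what reverses the effect, since the group is meta to a large group in the new pair and para to a large group in the earlier pair, and the cores differ as well. From the compounds shown here alone, it remains open what the change would do if only its place differed on a single core. Going by these compounds, how a hydroxyl or a plain amine in that place would compare with methoxy and dimethylamino is also open.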